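Working notes: anilino swap on the shared core

The compounds below may be only part of what the source reports. "The series", "measured", "known", "first", "only" and "open" are said of these compounds alone.

Measured so far:
compound 1 `CC(C)n1cnc2c(Nc3cccc(Cl)c3)nc(NCOCc3ccc(C(=O)Nc4ccccc4N)cc3)nc21`: 63.4%
compound 2 `Nc1ccccc1NC(=O)c1ccc(COCNc2nc(Nc3ccc(-c4ccccc4)cc3)c3ncn(C4CCCC4)c3n2)cc1`: 25.8%

In a functional assay on HCT-116 cells (Homo sapiens) for antiproliferative activity, read by CCK-8 assay, with a stated time of 72 h, tested at 8 uM (a lower number here means a weaker effect, a higher number a stronger effect of the compound at the concentration tested), compound 1 gives 63.4%, and compound 2 gives 25.8%. Of the two numbers, compound 2 stands lowest; the gap to compound 1 lies beyond the scatter.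

Compound 3 `Nc1ccccc1NC(=O)c1ccc(COCNc2nc(Nc3cccc(Cl)c3)c3ncn(C4CCCC4)c3n2)cc1` is not yet measured. Relative to compound 2 the change is 3-chlorophenyl in place of 4-phenylphenyl on a nitrogen on an aromatic ring. Compound 3 thereby carries the same 3-chlorophenyl on that nitrogen as compound 1, while the rest of compound 3 matches compound 2. Going by the values given here, no measured pair isolates this one change, so the size of the step can only be inferred from the two values shown.

Because compound 1 with the 3-chlorophenyl gives 63.4%, an upward step is expected in this assay, estimated as a number 26.2 percentage points higher from compound 2 to compound 3 (beyond the scatter), probably beyond the scatter but of uncertain size since the two measured compounds also differ elsewhere. For compound 3 the estimate in this assay is 52%, with a range from 32% to 70%.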

Compound 3, a percentage reported as inhibition, at one concentration (the size of the read-out at that concentration, not a potency): 40.6%
Estimate against measurement, compound 3: 11.4 percentage points above; the measured number falls inside the stated range.
By their numbers in this assay, from the lowest: compound 2; then compound 3; then compound 1.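

In this assay, going by these compounds alone, the swap of 4-phenylphenyl for 3-chlorophenyl on a nitrogen on an aromatic ring gives a number 14.8 percentage points higher from compound 2 to compound 3 (beyond the scatter) and so provides the first reading of this position with the rest of the molecule held fixed. The second single change, cyclopentyl in place of isopropyl on an aromatic nitrogen, gives a number 22.8 percentage points lower from compound 1 to compound 3 (beyond the scatter) with the 3-chlorophenyl unchanged. The read-out therefore responds to each of the two places on its own, and each step is modest in size, with compound 3 one change away from both compound 1 and compound 2. Within the data shown here, nothing measured so far offers a reason for either step.

Whether the two changes add up stays open, as the combination of isopropyl with 4-phenylphenyl is not among the compounds shown. Also open, from the compounds shown here alone, is how a phenyl carrying an amine or a carboxylic acid would read on that nitrogen, and how a longer chain such as n-butyl would read in place of cyclopentyl on the aromatic nitrogen.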